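A few compounds are considered here, and "the series" means these few. Any claim that something is new, unique, unknown or untested is made for them only; others in the source may bear on it.

Measured so far:
compound 1 `CCc1nc(N)nc2c1c(-c1ccc3oc(N)nc3c1)nn2C(C)C` — 62000 nM
compound 2 `COc1nc(N)nc2c1c(-c1ccc3oc(N)nc3c1)nn2C(C)C` — < 1000 nM

Among the compounds with values here, in a physicochemical assay for solubility, read by HPLC, in phosphate buffer, measured as kinetic solubility, with a stated time of 24 h, at 20 degrees C, at pH 7.4, tested at 100 uM (a lower number here means a less soluble compound, a higher number a more soluble compound), compound 1 gives 62000 nM, the only full number in the set. Compound 2 returns only a limit, < 1000 nM, as noted in the limit of < 1000 nM in this assay, at which 1 of the 2 values shown sits. Within the data shown here, the single measured step, an at least 62-fold lower number from compound 1 to compound 2 (1.79 log units; beyond the scatter), is large. Compound 3 `CC(C)n1nc(-c2ccc3oc(N)nc3c2)c2c(Cl)nc(N)nc21` differs from compound 1 by chloro in place of ethyl on an aromatic carbon. The measured step involves a different entering group at the same place, so it bears on compound 3 only loosely, yet it shows that exchanging the ethyl there can move the number far down. For compound 3 a smaller drop than that is expected, a 5.2-fold lower number from compound 1 to compound 3 (0.71 log units; beyond the scatter). The estimate for compound 3 is 12000 nM. Its expected range for compound 3 runs from 1500 nM to 60000 nM, and a limit reading remains possible.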

Compound 3, solubility: 2000 nM
The estimate for compound 3 lay 6.0-fold (0.78 log units) above the measured number; the range from low to high includes it.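

Chloro in place of ethyl on this aromatic carbon gives a 31-fold lower number from compound 1 to compound 3 (1.49 log units; beyond the scatter) in this assay and so provides the first full number for a replacement of ethyl at this position, with ethyl staying ahead of both replacements shown. The reading of compound 2 remains a limit of < 1000 nM and not a number. The comparison between the two replacements yields only an at least 2.0-fold higher number from compound 2 to compound 3 (0.30 log units; that floor lies within the scatter) and so does not set chloro apart from methoxy.

Whether the high number of compound 1 is particular to ethyl stays open, since the compounds shown include no longer chain such as propyl at this carbon. On these data alone, how an amine or a carboxylic acid would read there also remains open.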